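The source may report more compounds than this note shows. Statements on the series, on what has been measured and on what is new or still open speak of the compounds shown alone.

Among the compounds with values here, in a functional assay on brain (Rattus norvegicus, strain Wistar) for inhibition (on this read-out higher numbers stand for weaker inhibition and lower numbers for stronger inhibition), compound 1 `CCCCOc1ccc(-c2c(C)[nH]c(=O)n2C2CCCCC2)cc1` gives 13900 nM and compound 2 `CCCc1ccc(-c2c(C)[nH]c(=O)n2C2CCCCC2)cc1` gives 13900 nM, so compound 2 stands level with compound 1, the only other compound measured so far. Compound 3 `Cc1[nH]c(=O)n(C2CCCCC2)c1-c1ccc(OC(C)C)cc1` keeps the shared core but has isopropoxy in place of propyl on an aromatic carbon. Within the data shown here, one measured step bears on this change. Replacing butoxy with propyl, a swap of the same kind in reverse, gave no change at the digits printed from compound 1 to compound 2 (within the scatter). Compound 3 brings back a chain joined through oxygen, as in the butoxy of compound 1, whose value is 13900 nM. A single step is thin evidence, and isopropoxy itself has not been tested. Even so, no shift beyond the scatter is expected in this assay, and the expected change is a 1.1-fold lower number from compound 2 to compound 3 (0.03 log units; within the scatter). For compound 3, the estimated value is 13000 nM, within an expected range of 6000 nM to 30000 nM.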

Compound 3, half-maximal inhibitory concentration: 13000 nM
Compound 3: the middle estimate sits on the measured number at the digits printed, within the range that was stated.
By their numbers in this assay, from the lowest: compounds 3, 1 and 2 (each within the scatter of the next).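

In this assay, putting isopropoxy in place of propyl gives a 1.1-fold lower number from compound 2 to compound 3 (0.03 log units; within the scatter) and putting isopropyl in place of butyl on the oxygen gives a 1.1-fold lower number from compound 1 to compound 3 (0.03 log units; within the scatter) at the same place on the aromatic ring. The earlier pair had compared only butoxy with propyl, so this result adds a second group joined through oxygen, one with a different chain shape, and it too reads alike. Among these three compounds, then, neither the oxygen link nor the shape of the small chain moves the number beyond the scatter, and no measurement at hand explains this flat result.

A carboxylic acid, an amine or a much longer chain at this place could still behave differently. These three groups match one another, but that does not show that every group here would give the same reading.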